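Sulfonamide aryl substituent change in a pyrimidine series

The source may hold more compounds than are shown below. What is called first, only, known or untested is meant among the compounds shown, and "the series" means these compounds.

Of the compounds shown here, two have been measured in a functional assay on MDA-MB-468 cells (Homo sapiens) for antiproliferative activity, read by MTT assay; on this read-out lower numbers stand for stronger inhibition and higher numbers for weaker inhibition. Compound 1, `Cc1cc(Nc2ccc(F)cc2)nc(Nc2ccc(NS(=O)(=O)c3ccccc3OC(F)(F)F)cc2)n1`, gives 42200 nM in this assay. Compound 2, `COc1ccc(Nc2ccnc(Nc3ccc(NS(=O)(=O)c4ccc(OC)cc4)cc3)n2)cc1`, gives 14800 nM in this assay. On these two numbers compound 2 stands at the lower end, and its gap to compound 1 lies beyond the usual scatter. Among the compounds with values here, compound 1 and compound 2 differ in several places at once, so no single step between them can be read.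

Compound 3, `COc1ccc(Nc2ccnc(Nc3ccc(NS(=O)(=O)c4ccc(C(F)(F)F)cc4)cc3)n2)cc1`, is not yet measured. It differs from compound 2 in one place: trifluoromethyl in place of methoxy on an aromatic carbon. Within the data shown here, no measured pair shows this change, so there is no step to lean on. The expectation is a step from compound 2 to compound 3 of a 1.3-fold lower number from compound 2 to compound 3 (0.13 log units; within the scatter) in this assay, which is taken as no change beyond the scatter, with the direction open. For compound 3 the estimate in this assay is 11000 nM, within a range of 3500 nM to 35000 nM.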

Compound 3, half-maximal inhibitory concentration: > 50000 nM
Compound 3 gave a limit, no number; the forecaster's own chance of this, stated with the estimate: 10%; at least 4.5-fold (0.65 log units) between middle value and limit.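

The sulfonamide aryl position now has its first step in a single place: the change from 4-methoxyphenyl to 4-(trifluoromethyl)phenyl, para to a large group, gives an at least 3.3-fold higher number from compound 2 to compound 3 (0.52 log units; beyond the scatter) in this assay, so the read-out at this position depends on the group it carries, which the earlier pair, differing in several places at once, could not show. Compound 3 gives > 50000 nM, which is a limit of the assay and not a number. Within this single pair, methoxy therefore gives the lower number of the two groups, and the step has a minimum size but no measured size: the limit of > 50000 nM in this assay, at which 1 of the 3 values shown sits.

With only methoxy and trifluoromethyl compared here, the compounds shown do not separate what methoxy contributes from what trifluoromethyl takes away, and they leave open how an amine or a carboxylic acid at this same position would read in this assay. From the compounds shown here alone, whether the same change would give a step of similar direction on the core of compound 1 also stays open.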